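This account rests on a few compounds, and the source may have more. Where it says the series, first, only, none or still open, it means among the compounds named here.

Measured in a functional assay on V79 cells (Cricetulus griseus) for cytotoxicity, read by colony formation; a lower number here means a stronger inhibitor, a higher number a weaker inhibitor:
- compound 1 `NC1CCN(c2cc3c(c(O)c2F)c(=O)c(C(=O)O)cn3C2CC2)C1`: 72 ug/mL
- compound 2 `Nc1c(F)c(N2CCC(N)C2)c(F)c2c1c(=O)c(C(=O)O)cn2C1CC1`: 15 ug/mL

Compound 2, at 15 ug/mL, has the lower number of the two and is the stronger inhibitor, and its gap to compound 1 lies beyond the usual scatter. Compound 3 `NC1CCN(c2c(F)c(O)c3c(=O)c(C(=O)O)cn(C4CC4)c3c2F)C1` has not yet been measured. It carries hydroxy in place of amino on an aromatic carbon. Among the compounds with values here, no measured pair shows this change alone, so any forecast is loose. Compound 1, which also bears hydroxy, gives 72 ug/mL, so a moderately higher number, meaning a weaker inhibitor, is expected in this assay. The expected step is a 2.0-fold higher number from compound 2 to compound 3 (0.30 log units; within the scatter). For compound 3 the estimated value is 30 ug/mL, with an expected range of 10 ug/mL to 90 ug/mL.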

Compound 3, half-maximal inhibitory concentration: 43 ug/mL
For compound 3 the middle estimate is 1.4-fold (0.16 log units) below the measured one; low and high end bracket the measured number.
By their numbers in this assay, from the lowest: compound 2; then compounds 3 and 1 (each within the scatter of the next).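

In this assay, placing hydroxy instead of amino on this aromatic carbon, para to a fluoro group, gives a 2.9-fold higher number from compound 2 to compound 3 (0.46 log units; beyond the scatter), a modest but real weakening that the earlier pair could not isolate. A second single change, fluoro in place of hydrogen on an aromatic carbon, gives a 1.7-fold lower number from compound 1 to compound 3 (0.22 log units; within the scatter), which does not separate compound 1 from compound 3. No measurement here explains either step.

As far as these compounds go, whether methoxy or methylamino on this carbon would stay closer to amino or to hydroxy remains open. So does whether the amino-to-hydroxy step would hold on another core.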